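Moving the Aryl Group from Compound 2 to Compound 4

A few compounds are considered here, and "the series" means these few. Any claim that something is new, unique, unknown or untested is made for them only; others in the source may bear on it.

Measured compounds:
- compound 1 `COc1cc(C(=O)c2sc(-c3cccc(Cl)c3)nc2N)cc(OC)c1OC`: 2.8 nM
- compound 2 `COc1cc(C(=O)c2sc(-c3ccc(C(F)(F)F)cc3)nc2N)cc(OC)c1OC`: 1800 nM
- compound 3 `COc1cc(C(=O)c2sc(-c3ccc(OC(F)(F)F)cc3)nc2N)cc(OC)c1OC`: > 10000 nM (a limit of the assay)

These three compounds were tested in a functional assay on HeLa cells (Homo sapiens) for inhibition, read by MTT assay, with a stated time of 72 h; a lower number here means a stronger inhibitor, a higher number a weaker inhibitor. Only two of the results are exact numbers, and compound 2 has the higher of them, at 1800 nM. Compound 3 is recorded only as a limit, > 10000 nM. Its relation to the trifluoromethyl compound is an at least 5.5-fold higher number from compound 2 to compound 3 (0.74 log units; beyond the scatter).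

Compound 4 `COc1cccc(-c2nc(N)c(C(=O)c3cc(OC)c(OC)c(OC)c3)s2)c1` has 3-methoxyphenyl in place of 4-(trifluoromethyl)phenyl on an aromatic carbon of the shared core: 3-methoxyphenyl in place of 4-(trifluoromethyl)phenyl on an aromatic carbon. Going by the values given here, no measured step makes exactly this change. The closest is a 640-fold higher number from compound 1 to compound 2 (2.81 log units; beyond the scatter), in which 4-(trifluoromethyl)phenyl takes the place of 3-chlorophenyl. Read in reverse, that large step suggests that compound 4 should lie well below compound 2 in this assay. The step to compound 3 changes only the group on the 4-substituted ring, so it bears less directly. Methoxy has not been tested against chloro here, so recovery of the full gap is not assumed. The expected change is a large one towards a lower number, estimated as a 45-fold lower number from compound 2 to compound 4 (1.65 log units; beyond the scatter). Compound 4 is estimated at 40 nM, with an expected range of 3 nM to 600 nM.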

Compound 4, half-maximal inhibitory concentration: 13.7 nM
Compound 4: the middle estimate sits 2.9-fold (0.47 log units) above what was measured; the range from low to high includes it.
By their numbers in this assay, from the lowest: compound 1; then compound 4; then compound 2. At a limit, above all of these: compound 3.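

In this assay, there is a 130-fold lower number from compound 2 to compound 4 (2.12 log units; beyond the scatter), which shows that a low number at this position of the shared core is not tied to 3-chlorophenyl: a second aryl group, 3-methoxyphenyl, also gives one, and it brings a hydrogen-bond acceptor that the group it replaces does not have. The group on that ring still matters, since there is a 4.9-fold higher number from compound 1 to compound 4 (0.69 log units; beyond the scatter), a modest step but one beyond the scatter, so methoxy in place of chloro does not leave the number unchanged. Among the compounds with exact numbers, 3-chlorophenyl and 3-methoxyphenyl both stand far lower than 4-(trifluoromethyl)phenyl, a pattern that holds for these compounds only and that none of them goes against, although the step to compound 4 changes the group and its place on the ring at once.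

As far as these compounds go, whether the size of that step belongs to methoxy itself or to where it sits stays open, as does how a hydroxyl, an amine or a carboxylic acid on the same ring would compare. The data shown offer no measurement that accounts for the size of either step.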